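Removing a Methyl from the Core: Expected Effect on Inhibition

The compounds below may be only part of what the source reports. "The series", "measured", "known", "first", "only" and "open" are said of these compounds alone.

Compound 1 `c1ncc2c(n1)CCCCCCCCCC2` and compound 2 `Cc1ncc2c(n1)CCCCCCCCCC2` share one core, while compound 3 `Cc1nnc2c([n+]1[O-])CC(C(C)(C)C)CC2` and compound 4 `CC(C)(C)C1CCc2nnc[n+]([O-])c2C1` share another; the difference between the two cores is not broken down here. In a functional assay on the whole organism for inhibition, with Rattus norvegicus as the target, with stated times of 1 h and 3.5 h, at a dose of 100 mg/kg by the oral route (on this read-out lower numbers stand for less inhibition and higher numbers for more inhibition at the one dose given (going by the name of the read-out)), compound 1 gives < 5%, which is a limit of the assay rather than a number. In this assay compound 2 also gives < 5%, again a limit. The change from compound 2 to compound 1 is hydrogen in place of methyl on an aromatic carbon, and a step that the two limits leave unreadable from compound 2 to compound 1 because of the limit of < 5% in this assay, at which 2 of the 3 values shown sit. Compound 3 gives 48% in this assay, the only number shown. The change to compound 4 is the same kind of change, (hydrogen in place of methyl on an aromatic carbon), though here the ring carries 3 nitrogen and the place is ortho to a group of 1 heavy atom, two atoms from the ring nitrogen. Compound 4 is expected to give about 35% in this assay. That estimate means a step of a number 13 percentage points lower from compound 3 to compound 4 (beyond the scatter) and rests on compound 3 at 48%, since the earlier step that the two limits leave unreadable from compound 2 to compound 1 gives no readable size.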

Compound 4, a percentage reported as inhibition, in the whole organism at one dose (the size of the read-out at that dose, not a potency): 36%
Beside the measured number, compound 4's estimate is 1 percentage points below it; low and high end bracket the measured number.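

In this assay, putting hydrogen in place of methyl on an aromatic carbon gives a number 12 percentage points lower from compound 3 to compound 4 (beyond the scatter). The same change cannot be read in the core shared by compound 1 and compound 2, because neither compound has a value that can be compared: the limit of < 5% in this assay, at which 2 of the 4 values shown sit. So this pair gives a size for the change in the core of compound 3 only, and it does not show whether that size, or even that direction, carries over to the other core.

The compounds shown leave open what other groups would do at this place, such as an amine, a carboxylic acid or a longer chain. They also leave open whether the step would hold in further cores.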